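The source may hold more compounds than are shown below. What is called first, only, known or untested is meant among the compounds shown, and "the series" means these compounds.

Working notes on the series. In an assay on isolated protein for binding affinity to leukotriene B4 receptor 1 (Homo sapiens) (a higher number here means a weaker inhibitor, a lower number a stronger inhibitor), compound 1 `COc1ccc(CCCCOc2ccc(CSc3ccccc3)nc2/C=C/C(=O)O)cc1` gives 2.8 nM, compound 2 `COc1ccc(CCCCOc2ccc(CSc3c(Cl)cccc3Cl)nc2/C=C/C(=O)O)cc1` gives 1.5 nM and compound 3 `O=C(O)/C=C/c1nc(CSc2c(Cl)cccc2Cl)ccc1OCCc1ccc(Cl)cc1` gives 1.3 nM; compound 3 has the lowest number of the three, though its gap to compound 2 is within the scatter, and only its gap to compound 1 is beyond it. Compound 4 `O=C(O)/C=C/c1nc(CSc2c(Cl)cccc2Cl)ccc1OCc1ccc(F)cc1` differs from compound 3 as follows: 4-fluorophenyl in place of 4-chlorobenzyl on a saturated chain carbon bound to an oxygen on an aromatic ring. Of the measured steps, a 1.2-fold lower number from compound 2 to compound 3 (0.06 log units; within the scatter) altered the same chain region and stayed within the scatter; a 1.9-fold lower number from compound 1 to compound 2 (0.27 log units; within the scatter) concerned the sulfur-bound ring and was also within the scatter. For the measured compounds named here, no step here is beyond the scatter, so no step beyond the scatter is expected in this assay from compound 3 to compound 4, a 1.5-fold higher number from compound 3 to compound 4 (0.19 log units; within the scatter). Compound 4 is therefore expected near 2 nM, between 0.7 nM and 6 nM.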

Compound 4, inhibition constant: 12 nM
Compound 4: middle estimate off by 6.0-fold (0.78 log units), on the low side, outside the stated range (above it).
By their numbers in this assay, from the lowest: compounds 3, 2 and 1 (each within the scatter of the next, the first and the last beyond it); then compound 4.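

In this assay, this chain region proves less forgiving than a 1.2-fold lower number from compound 2 to compound 3 (0.06 log units; within the scatter) suggested, which stayed within the scatter: shortening to the 4-fluorobenzyl ether gives a 9.2-fold higher number from compound 3 to compound 4 (0.97 log units; beyond the scatter) and, against the longer chain, an 8.0-fold higher number from compound 2 to compound 4 (0.90 log units; beyond the scatter) and both steps lie beyond the scatter. The position therefore responds to this change, even though 2-(4-chlorophenyl)ethyl and the longer 3-(4-methoxyphenyl)propyl chain sit within the scatter of each other. Nothing on hand accounts for the rise. Chain length and the fluorine in place of chlorine change together here, so the compounds shown leave open which one carries the rise. A 2-(4-fluorophenyl)ethyl group on the same oxygen would separate the two.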